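From Phenyl to Benzyl on the Nitrogen

A few compounds are considered here, and "the series" means these few. Any claim that something is new, unique, unknown or untested is made for them only; others in the source may bear on it.

In a functional assay on BV-2 cells (Mus musculus) for inhibition, read by Griess assay, with a stated time of 24 h (a higher number here means a weaker inhibitor, a lower number a stronger inhibitor), compound 1 (`COc1ccc(Br)cc1-c1ccn(Cc2ccccc2)n1`) gives > 200000 nM as a limit of the assay and not a number. Compound 2 (`C=CCc1ccc(OC)c(-c2ccn(CC=C)n2)c1`) likewise gives > 200000 nM as a limit and not a number. Within the data shown here, compound 3 (`C=CCc1ccc(OC)c(-c2ccn(-c3ccccc3)n2)c1`) stands at 8920 nM and holds the only actual number among the three.

Among the measured compounds shown here, the one measured step that bears directly on this nitrogen is an at least 22-fold lower number from compound 2 to compound 3 (1.35 log units; beyond the scatter) with phenyl in place of allyl on an aromatic nitrogen. Its size is known only as a bound (the limit of > 200000 nM in this assay, at which 2 of the 3 values shown sit).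

Compound 4 (`C=CCc1ccc(OC)c(-c2ccn(Cc3ccccc3)n2)c1`) departs from compound 3 in one place: benzyl in place of phenyl on an aromatic nitrogen. For the measured compounds named here, no measured step makes this exchange directly. Compound 1 also carries benzyl on that nitrogen, and its > 200000 nM is again only a limit. With that value and the large step to compound 3 in view, a move toward a higher number, meaning a weaker inhibitor, is expected rather than no change. The expected change is a 4.5-fold higher number from compound 3 to compound 4 (0.65 log units; beyond the scatter) on this estimate. In this assay compound 4 is expected at 40000 nM with an estimated range of 9000 nM to 150000 nM overall.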

Compound 4, half-maximal inhibitory concentration: 36000 nM
The estimate for compound 4 lay 1.1-fold (0.05 log units) above the measured number; the range from low to high includes it.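

With compound 4, the exchange of phenyl for benzyl on the aromatic nitrogen can be read directly in this assay: the step is a 4.0-fold higher number from compound 3 to compound 4 (0.61 log units; beyond the scatter), so the gain seen with phenyl is not kept in full once benzyl takes its place. Benzyl does not fall back to the level of allyl, however, as the step of an at least 5.5-fold lower number from compound 2 to compound 4 (0.74 log units; beyond the scatter) shows, and it places compound 4 between the two other groups on this nitrogen, with compound 3 ahead of it and compound 2 behind it. The benzyl-bearing pair also gives the first reading away from the nitrogen, since allyl in place of bromo on an aromatic carbon yields an at least 5.5-fold lower number from compound 1 to compound 4 (0.74 log units; beyond the scatter), and this step, like the one before it, has a size known only as a bound: the limit of > 200000 nM in this assay, at which 2 of the 4 values shown sit.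

The compounds shown leave open how a longer chain between the aromatic nitrogen and the phenyl ring, such as phenethyl, would compare with benzyl and phenyl. They also leave open how phenyl or benzyl carrying an amine or a carboxylic acid would read in this assay.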